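Iodo to 2-chloroethenyl at the limit of the assay

This account rests on a few compounds, and the source may have more. Where it says the series, first, only, none or still open, it means among the compounds named here.

In a functional assay on CCRF-HSB-2 cells (Homo sapiens) for antiproliferative activity (on this read-out lower numbers stand for stronger inhibition and higher numbers for weaker inhibition), compound 1 `CCc1cn([C@@H]2S[C@H](CO)[C@@H](O)[C@@H]2O)c(=O)[nH]c1=O` gives > 100 ug/mL, which is a limit. Compound 2 `O=c1[nH]c(=O)n([C@@H]2S[C@H](CO)[C@@H](O)[C@@H]2O)cc1I` gives > 100 ug/mL, also a limit. Among the compounds with values here, the series so far offers only (the limit of > 100 ug/mL in this assay, at which 2 of the 2 values shown sit). Within the data shown here, the one measured step is a step that the two limits leave unreadable from compound 1 to compound 2, and it gives no size to carry forward. Compound 3 `O=c1[nH]c(=O)n([C@@H]2S[C@H](CO)[C@@H](O)[C@@H]2O)cc1/C=C/Cl` has 2-chloroethenyl in place of iodo on an aromatic carbon. No shift beyond the scatter is expected in this assay, the estimated step being a step that the limit leaves unreadable from compound 2 to compound 3. Compound 3 is expected at 120 ug/mL, with an estimated range of 40 ug/mL to 300 ug/mL.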

Compound 3, half-maximal inhibitory concentration: > 100 ug/mL
Compound 3: only a limit was reported (the forecaster's own chance of this, stated with the estimate: 80%); the middle value lies beyond the limit too.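

Within the data shown here, no step among compound 1, compound 2 and compound 3 can be read in this assay, since all three sit at the same limit: the limit of > 100 ug/mL in this assay, at which 3 of the 3 values shown sit. Going by these compounds, whether ethyl, iodo and 2-chloroethenyl differ in antiproliferative activity remains open.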